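Two aryl ureas and a phenol awaiting its number

The source may hold more compounds than are shown below. What is called first, only, known or untested is meant among the compounds shown, and "the series" means these compounds.

The series holds two measured compounds of a shared core. Compound 1 `Cc1cc(C)cc(N2CCNC(=O)N2)c1` in an assay on RBL-1 cells for inhibition of Polyunsaturated fatty acid 5-lipoxygenase (Rattus norvegicus) (a higher number here means a weaker inhibitor, a lower number a stronger inhibitor), gives 12000 nM. Compound 2 `COc1cccc(N2CCNC(=O)N2)c1` in this assay gives 47000 nM, the higher of the two numbers, and the gap to compound 1 lies beyond the scatter of repeated measurements. Compound 3 `O=C1NCCN(c2cccc(O)c2)N1` has not yet been measured. It differs from compound 2 in one place: hydrogen in place of methyl on an oxygen on an aromatic ring. Within the data shown here, no pair of measured compounds shows this change, so nothing in the data tells how large a step it brings. Compound 3 is therefore expected to stay near compound 2, with a step from a 1.6-fold lower number from compound 2 to compound 3 (0.19 log units; within the scatter) that may not exceed the scatter. The estimate for compound 3 in this assay is 30000 nM, within a range from 8000 nM to 120000 nM.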

Compound 3, half-maximal inhibitory concentration: 32000 nM
Compound 3: the middle estimate sits 1.1-fold (0.03 log units) below what was measured, and the stated range covers the measured number.
By their numbers in this assay, from the lowest: compound 1; then compounds 3 and 2 (each within the scatter of the next).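

In this assay, methoxy giving way to hydroxy on the aromatic ring brings a 1.5-fold lower number from compound 2 to compound 3 (0.17 log units; within the scatter). This pair gives the series its first reading of this change: at this position, the methyl on the oxygen can be replaced by hydrogen without a shift that stands out from repeated measurements. Among these compounds, the single pair shows only that the two numbers cannot be told apart, and no measurement at hand bears on why this is so.

Open, on these data alone, is whether a larger group on that oxygen, such as ethoxy or a longer chain, or an amine in place of the hydroxy, would move the number beyond the scatter. Among the compounds shown here, also open is whether methoxy to hydroxy would read the same on an aromatic ring carrying other groups, since only this one pair shows the change.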